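The compounds below may be only part of what the source reports. "The series", "measured", "known", "first", "only" and "open" are said of these compounds alone.

Measured so far:
Compound 1 `CCN(CC)C(=O)CCC(=O)Oc1ccc(C[C@H]2C(=O)OC[C@@H]2Cc2ccc(OC)c(OC)c2)cc1OC`: 213000 nM
Compound 2 `COc1ccc(C[C@H]2COC(=O)[C@@H]2Cc2ccc(OC(=O)CCC(=O)N3CCCC3)c(OC)c2)cc1OC`: 201000 nM

In an ADME assay on HeLa cells (Homo sapiens) for cytotoxicity, read by MTT assay (on this read-out higher numbers stand for weaker inhibition and lower numbers for stronger inhibition), compound 2 gives 201000 nM, which cannot be told apart from the other measured compound, compound 1 at 213000 nM. The next compound to be tested is compound 3 `CCN1CCN(C(=O)CCC(=O)Oc2ccc(C[C@H]3C(=O)OC[C@@H]3Cc3ccc(OC)c(OC)c3)cc2OC)CC1`. Its structural change is 4-ethylpiperazin-1-yl in place of pyrrolidin-1-yl on a carbonyl carbon; in words, 4-ethylpiperazin-1-yl stands in place of pyrrolidin-1-yl on a carbonyl carbon.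

Among the compounds with values here, only one measured step bears on this change, as it also exchanges the group on that carbonyl carbon: a 1.1-fold lower number from compound 1 to compound 2 (0.03 log units; within the scatter). That single step is small, but it involves neither 4-ethylpiperazin-1-yl nor any other six-membered ring in that place, so it is only a weak guide. Within the data shown here, no measured compound carries the entering group. On this evidence, no shift beyond the scatter is expected in this assay, and no direction can be favoured with confidence. The expected step is a 1.1-fold lower number from compound 2 to compound 3 (0.02 log units; within the scatter). For compound 3 the estimated value is 190000 nM, with an expected range from 80000 nM to 350000 nM.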

Compound 3, half-maximal inhibitory concentration: 190000 nM
For compound 3 middle estimate and measured number coincide at the digits printed, within the range that was stated.
By their numbers in this assay, from the lowest: compounds 3, 2 and 1 (each within the scatter of the next).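

In this assay, 4-ethylpiperazin-1-yl in place of pyrrolidin-1-yl on the carbonyl carbon gives a 1.1-fold lower number from compound 2 to compound 3 (0.02 log units; within the scatter), and the same group in place of diethylamino gives a 1.1-fold lower number from compound 1 to compound 3 (0.05 log units; within the scatter). The earlier compounds had shown only an open-chain group and a five-membered ring at this place, whereas compound 3 shows that a six-membered non-aromatic ring with 2 hetero atoms, carrying an ethyl group and counted with a hydrogen-bond acceptor that pyrrolidin-1-yl lacks, also leaves the number within the scatter of both. Across these three compounds, then, the exchanges of the group on this carbonyl carbon produce no step beyond the scatter, none of the three goes against that, and nothing measured offers an explanation for it.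

Going by these compounds, it remains open whether any group at this place would move the number, for instance a carboxylic acid in place of the amide, a primary amide or an amine with a free hydrogen on its nitrogen. Also open, on these data alone, is whether a longer chain leading to the same amide, or a change elsewhere on the shared core, would do so.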